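Two measured compounds and one still to be tested

The compounds below may be only part of what the source reports. "The series", "measured", "known", "first", "only" and "open" are said of these compounds alone.

The study compares compounds built on a shared core and tested in an ADME assay on microsomes from liver (Homo sapiens) for metabolic stability; a lower number here means slower removal, a higher number faster removal of the compound. Compound 1 `COc1cc([C@](O)(CCN(C)C)[C@@H](c2cc3cc(Br)ccc3nc2OC)c2ccnc(OC)c2OC)cc(OC(C)C)n1` gives 6.4 uL/min in this assay. Compound 2 `COc1cccc([C@H](c2cc3cc(Br)ccc3nc2OC)[C@@](O)(CCN(C)C)c2cc(SC)nc(SC)c2)c1F` gives 3.4 uL/min in this assay, the lower of the two numbers; its gap to compound 1 lies within the usual scatter of repeated measurements, so the two cannot be ordered on this evidence. Among the measured compounds shown here, no pair of the measured compounds differs at a single position, so no step between them can be read directly.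

Compound 3 `COc1nc2ccc(Br)cc2cc1[C@@H](c1ccnc(OC)c1OC)[C@@](O)(CCN(C)C)c1cc(SC)nc(SC)c1` has not yet been measured. It differs from compound 2 at one place: 2,3-dimethoxypyridin-4-yl in place of 2-fluoro-3-methoxyphenyl on a saturated chain carbon bound to an aromatic carbon and a saturated chain carbon. The group that enters is also carried by compound 1, which gives 6.4 uL/min in this assay, while the rest of compound 3 matches compound 2.

On that basis, the step from compound 2 to compound 3 is expected to be small, a 1.5-fold higher number from compound 2 to compound 3 (0.17 log units; within the scatter), a rise that most likely stays within the scatter. Compound 3 is therefore estimated at 5 uL/min in this assay, with a range from 2 uL/min to 12 uL/min.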

Compound 3, intrinsic clearance in a liver preparation (reported as CLH), per the amount of preparation that the assay uses: 8.8 uL/min
Estimate against measurement, compound 3: 1.8-fold (0.25 log units) below, and the stated range covers the measured number.
By their numbers in this assay, from the lowest: compounds 2, 1 and 3 (each within the scatter of the next, the first and the last beyond it).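

In this assay, 2,3-dimethoxypyridin-4-yl in place of 2-fluoro-3-methoxyphenyl, on a saturated chain carbon bound to an aromatic carbon and a saturated chain carbon, gives a 2.6-fold higher number from compound 2 to compound 3 (0.41 log units; beyond the scatter), so this place now has a directly read step, and it lies beyond the scatter. The second place, a saturated chain carbon bound to an oxygen on a saturated carbon and two saturated chain carbons, also gets its first reading: a group of 10 heavy atoms with 2 sulfur in place of a group of 12 heavy atoms with 2 oxygen gives a 1.4-fold higher number from compound 1 to compound 3 (0.14 log units; within the scatter), and with 2,3-dimethoxypyridin-4-yl present, these two groups cannot be told apart. Nothing available here accounts for the rise at the first place.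

The compounds shown leave open which part of the first change carries the step, as the ring nitrogen, the added oxygen and the lost fluorine all change together; a 2,3-dimethoxyphenyl group at that place would separate the ring nitrogen from the rest. Also open, from the compounds shown here alone, is whether the step keeps its size when the group of 12 heavy atoms stands at the second place.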